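The source may report more compounds than this note shows. Statements on the series, on what has been measured and on what is new or still open speak of the compounds shown alone.

Among the measured compounds shown here, compound 2 `CCOC(=O)c1c(CSc2cccc(Cl)c2)n(C)c2ccc(O)cc12` is one of two compounds measured in an assay for inhibition of Polyunsaturated fatty acid 5-lipoxygenase (Homo sapiens), read by HPLC, with a stated time of 10 min (a lower number here means a stronger inhibitor, a higher number a weaker inhibitor), where compound 2 gives 3800 nM. Its companion, compound 1 `CCOC(=O)c1c(CSc2ccc(OC)cc2)n(C)c2ccc(O)cc12`, gives 2300 nM in this assay. The step of a 1.7-fold higher number from compound 1 to compound 2 (0.22 log units; within the scatter) lies within the scatter, so compound 2 cannot be set apart from compound 1 on these numbers. Compound 3 `CCOC(=O)c1c(CSc2ccc(F)cc2F)n(C)c2ccc(O)cc12` has not yet been measured in this assay. It differs from compound 2 by 2,4-difluorophenyl in place of 3-chlorophenyl on a sulfur. For the measured compounds named here, the only measured step that bears on this change is the exchange of the ring on the sulfur from compound 1 to compound 2, which stayed within the scatter. On that basis compound 3 is expected to show no movement beyond the scatter in this assay, a step of a 1.3-fold lower number from compound 2 to compound 3 (0.10 log units; within the scatter). The estimate for compound 3 is therefore 3000 nM, with a range from 1200 nM to 8000 nM.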

Compound 3, half-maximal inhibitory concentration: 3200 nM
For compound 3 the middle estimate is 1.1-fold (0.03 log units) below the measured one, and the stated range covers the measured number.
By their numbers in this assay, from the lowest: compounds 1, 3 and 2 (each within the scatter of the next).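

Putting 2,4-difluorophenyl on the sulfur in place of 3-chlorophenyl gives a 1.2-fold lower number from compound 2 to compound 3 (0.07 log units; within the scatter) in this assay, and putting it there in place of 4-methoxyphenyl gives a 1.4-fold higher number from compound 1 to compound 3 (0.14 log units; within the scatter). Among the compounds shown here, the earlier pair showed only one exchange on this sulfur, whereas there are now three different substituted phenyl rings at this place, and none of the three compounds separates from the others. No measurement is at hand that would explain this flat result.

The compounds leave open whether a group other than a substituted phenyl ring on the sulfur, such as an amine, a carboxylic acid or a longer chain, would move the number beyond the scatter. All three also share the same core, so they say nothing about changes made elsewhere in it.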